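A few compounds are considered here, and "the series" means these few. Any claim that something is new, unique, unknown or untested is made for them only; others in the source may bear on it.

Compound 1, `CCOc1ccc(CCCN2CC=C(CCC(=O)NO)C2=O)cc1`: 5100 nM
Compound 2, `Cc1ccc(CCCN2CC=C(CCC(=O)NO)C2=O)cc1`: 5100 nM

In a functional assay on HCT-15 cells (Homo sapiens) for inhibition, read by sulforhodamine B assay (on this read-out higher numbers stand for weaker inhibition of growth and lower numbers for stronger inhibition of growth), compound 1 gives 5100 nM, and compound 2 gives 5100 nM. Compound 2 stands level with compound 1: the step of no change at the digits printed from compound 1 to compound 2 (within the scatter) lies within the scatter. Compound 3, `CC(C)c1ccc(CCCN2CC=C(CCC(=O)NO)C2=O)cc1`, differs from compound 2 by isopropyl in place of methyl on an aromatic carbon. For the measured compounds named here, the only measured step that bears on this change is no change at the digits printed from compound 1 to compound 2 (within the scatter), a swap at the same aromatic carbon that left the growth inhibition unchanged. Compound 3 is therefore expected to give 5100 nM, with a range from 2500 nM to 10500 nM. The expected step of no change at the digits printed from compound 2 to compound 3 (within the scatter) is none beyond the scatter.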

Compound 3, concentration for 50% growth inhibition: 5100 nM
Estimate against measurement, compound 3: no gap at the digits printed; low and high end bracket the measured number.
By their numbers in this assay, from the lowest: compounds 1, 2 and 3 (each within the scatter of the next).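

In this assay, isopropyl in place of methyl on the aromatic carbon para to a large group gives no change at the digits printed from compound 2 to compound 3 (within the scatter), so this position accepts 3 heavy atoms as readily as 1 in this read-out. Isopropyl in place of ethoxy gives no change at the digits printed from compound 1 to compound 3 (within the scatter), which places all three groups level at this carbon. No measurement is available that accounts for this flat result.

On these data alone, whether an amine, a carboxylic acid or a longer chain at this carbon would also read level remains open. So does whether any of these groups would behave the same way elsewhere on the ring.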